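Aryl exchange at the double-bonded carbon: estimate for compound 3

The source may hold more compounds than are shown below. What is called first, only, known or untested is meant among the compounds shown, and "the series" means these compounds.

Compound 1 `Nc1nc(N/N=C/c2ccc(Br)cn2)nc2c1ncn2[C@@H]1O[C@H](CO)[C@@H](O)[C@H]1O` and compound 2 `Nc1nc(N/N=C/c2ccc(N3CCCC3)cc2)nc2c1ncn2[C@@H]1O[C@H](CO)[C@@H](O)[C@H]1O` share one core and differ only at the carbon with a double bond to nitrogen. For the measured compounds named here, in an assay on CHO-K1 cells for displacement of a labelled ligand from adenosine receptor A1 (Homo sapiens), read by scintillation counting, with a stated time of 60 min (on this read-out higher numbers stand for weaker inhibition and lower numbers for stronger inhibition), compound 1 gives 4.7 nM, and compound 2 gives 5.1 nM; the step of a 1.1-fold higher number from compound 1 to compound 2 (0.04 log units; within the scatter) leaves compound 2 within the scatter of compound 1, the only other number. Compound 3 `Nc1nc(N/N=C/c2ccc(Cl)c(C(F)(F)F)c2)nc2c1ncn2[C@@H]1O[C@H](CO)[C@@H](O)[C@H]1O` carries 4-chloro-3-(trifluoromethyl)phenyl in place of 4-(pyrrolidin-1-yl)phenyl on a carbon with a double bond to nitrogen. Going by the values given here, the single step bearing on this place, a 1.1-fold higher number from compound 1 to compound 2 (0.04 log units; within the scatter), stayed within the scatter, so for compound 3 no shift beyond the scatter is expected, a 1.2-fold higher number from compound 2 to compound 3 (0.07 log units; within the scatter). Compound 3 is estimated at 6 nM, with a range from 2 nM to 20 nM.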

Compound 3, inhibition constant: > 10000 nM
Compound 3 gave a limit, no number (the forecaster's own chance of this, stated with the estimate: 3%); middle value at least 1600-fold (3.22 log units) away from the limit.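

The change to 4-chloro-3-(trifluoromethyl)phenyl gives an at least 1900-fold higher number from compound 2 to compound 3 (3.29 log units; beyond the scatter), and against 5-bromopyridin-2-yl it gives an at least 2100-fold higher number from compound 1 to compound 3 (3.32 log units; beyond the scatter). Compound 3 gives a limit and not a number: the limit of > 10000 nM in this assay, at which 1 of the 3 values shown sits.

The closeness of compound 1 and compound 2 therefore does not extend to every aryl group on the carbon with a double bond to nitrogen, and this place can separate aryl groups sharply. It remains open whether the chloro or the trifluoromethyl group accounts for the step, since a phenyl carrying only one of them is not among the compounds shown. As far as these compounds go, how a phenyl carrying an amine or a carboxylic acid would read also stays open.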